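Decyl gives way to hex-1-en-1-yl in compound 3

The source may hold more compounds than are shown below. What is called first, only, known or untested is meant among the compounds shown, and "the series" means these compounds.

Among the measured compounds shown here, in a toxicity assay on cells (Erythrocyte, Homo sapiens) for cytotoxicity, read by hemolysis (a higher number here means that more compound is needed for the effect, a lower number that less compound is needed), compound 2 `CCCCCCCCCCCCCCCCCC(=O)NCc1ccc(C(=O)N[C@H](C(=O)O)[C@@H](C)CC)cc1` gives 30 ug/mL, the only true number so far. Compound 1 `CCCCCCCCCC(=O)NCc1ccc(C(=O)N[C@H](C(=O)O)[C@@H](C)CC)cc1` gives > 1000 ug/mL, which is a limit of the assay and not a number. Compound 3 `CCCC/C=C\CCCCCCCC(=O)NCc1ccc(C(=O)N[C@H](C(=O)O)[C@@H](C)CC)cc1` follows with hex-1-en-1-yl in place of decyl on a saturated chain carbon, seven bonds along the chain from a carbonyl carbon. For the measured compounds named here, only one measured step bears on this, the gain of octyl in place of hydrogen, an at least 33-fold lower number from compound 1 to compound 2 (1.52 log units; beyond the scatter), which is large and beyond the scatter. Compound 3 loses part of such a chain, so a partial reversal of that step is expected. Going by the values given here, no measured step involves a double bond. The expected change is an 8.3-fold higher number from compound 2 to compound 3 (0.92 log units; beyond the scatter), a move to a higher number in this assay. For compound 3 the estimate is 250 ug/mL, with an expected range of 80 ug/mL to 800 ug/mL.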

Compound 3, half-maximal effective concentration: 350 ug/mL
Estimate against measurement, compound 3: 1.4-fold (0.15 log units) below; measured number inside the range.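

In this assay, this position responds strongly to more than the simple addition of chain: replacing decyl with hex-1-en-1-yl, seven bonds along the chain from a carbonyl carbon, gives a 12-fold higher number from compound 2 to compound 3 (1.07 log units; beyond the scatter) and removes much of the gain seen with the longer chain. Hex-1-en-1-yl in place of ethyl still gives an at least 2.8-fold lower number from compound 1 to compound 3 (0.45 log units; beyond the scatter) and so places this group between the two earlier ones, with no compound among the three going against that order. Compound 1 remains at a limit of the assay, > 1000 ug/mL and not a number: the limit of > 1000 ug/mL in this assay, at which 1 of the 3 values shown sits.

Compound 3 changes chain length and adds a double bond in one step, so the contribution of each remains unresolved. A saturated hexyl group at this place, or the same chain ending in a carboxylic acid or an amine, would address questions these compounds leave open.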